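Trimming a Methoxy Group: Expected Effect on Growth Inhibition

The source may hold more compounds than are shown below. What is called first, only, known or untested is meant among the compounds shown, and "the series" means these compounds.

Of the compounds shown here, three have been measured in a functional assay on SK-MEL-28 cells (Homo sapiens) for inhibition, read by sulforhodamine B assay, with a stated time of 48 h; a lower number here means a stronger inhibitor of growth, a higher number a weaker inhibitor of growth. Compound 1 `N=C(N)c1ccc(-c2ccc(-c3cc(Cl)cc(Cl)c3)s2)s1` gives 1830 nM, compound 2 `COc1ccc(-c2ccc(-c3ccc(C(=N)N)o3)o2)cc1` gives 1670 nM, and compound 3 `N=C(N)c1ccc(-c2ccc(-c3cncc4ccccc34)s2)s1` gives 1640 nM. Compound 2 has the second highest of these three numbers, but its gaps to compound 3 and to compound 1 both lie within the usual scatter, so the three cannot be ranked.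

Compound 4 `N=C(N)c1ccc(-c2ccc(-c3ccccc3)o2)o1` has not yet been measured. It differs from compound 2 in one place: hydrogen in place of methoxy on an aromatic carbon. Going by the values given here, no measured pair shows this kind of change, so there is no step to lean on. The expectation is a change no larger than the scatter, leaning slightly toward a weaker inhibitor, with the step from compound 2 to compound 4 expected as a 1.3-fold higher number from compound 2 to compound 4 (0.12 log units; within the scatter). Compound 4 is therefore estimated at 2200 nM, between 900 nM and 5500 nM.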

Compound 4, concentration for 50% growth inhibition: 1900 nM
Beside the measured number, compound 4's estimate is 1.2-fold (0.06 log units) above it; the measured number falls inside the stated range.
By their numbers in this assay, from the lowest: compounds 3, 2, 1 and 4 (each within the scatter of the next).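

In this assay, going by these compounds alone, putting hydrogen in place of methoxy gives a 1.1-fold higher number from compound 2 to compound 4 (0.06 log units; within the scatter), the first comparison here of compounds that differ in one place. On this aromatic carbon, para to a large group, the methoxy can therefore be removed without a shift beyond the scatter. Nothing available explains this result.

Compound 2 and compound 4 compare only methoxy and hydrogen at this position. From the compounds shown here alone, whether an amine, a carboxylic acid or a longer chain such as butoxy would move the number beyond the scatter remains open.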